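A few compounds are considered here, and "the series" means these few. Any claim that something is new, unique, unknown or untested is made for them only; others in the source may bear on it.

Compound 1, `Cc1cc(C)cc(NC(=O)COc2cc(C)nc3ccc(F)cc23)c1`: 63100 nM
Compound 2, `COc1ccc2nc(C)cc(OCC(=O)NCc3cc(C)cc(C)c3)c2c1`: > 100000 nM
Compound 3, `COc1ccc2nc(C)cc(OCCNc3cc(C)cc(C)c3)c2c1`: 31600 nM

In a toxicity assay on HepG2 cells (Homo sapiens) for inhibition, read by CellTiter-Glo, with a stated time of 48 h (on this read-out higher numbers stand for weaker inhibition and lower numbers for stronger inhibition), compound 2 stands at a limit of the assay, > 100000 nM, and no number is known for it. This is the limit of > 100000 nM in this assay, at which 1 of the 3 values shown sits. Compound 1 gives 63100 nM and compound 3 gives 31600 nM, both weak. Compound 4, `COc1ccc2nc(C)cc(OCC(=O)Nc3ccc(F)cc3)c2c1`, differs from compound 2 by 4-fluorophenyl in place of 3,5-dimethylbenzyl on an amide-type nitrogen. Among the measured compounds shown here, no measured pair follows this change, so the expectation rests only on the three weak values shown. The step of an at least 1.2-fold lower number from compound 2 to compound 4 (0.09 log units; that floor lies within the scatter) is expected to be small, toward stronger inhibition if anything, and may not exceed the scatter. Compound 4 is expected to give 80000 nM, in a range from 30000 nM to 200000 nM.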

Compound 4, half-maximal inhibitory concentration: 63100 nM
Estimate against measurement, compound 4: 1.3-fold (0.10 log units) above; the range from low to high includes it.
By their numbers in this assay, from the lowest: compounds 3, 1 and 4 (each within the scatter of the next). At a limit, above all of these: compound 2.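

In this assay, among the compounds shown here, 4-fluorophenyl in place of 3,5-dimethylbenzyl on an amide-type nitrogen gives an at least 1.5-fold lower number from compound 2 to compound 4 (0.19 log units; that floor lies within the scatter), the first step that can be read at this position. It shows that this place can carry a group that returns a number, though the floor of the step does not go beyond the scatter. The step has only a floor because compound 2 holds a limit of the assay and no number: the limit of > 100000 nM in this assay, at which 1 of the 4 values shown sits.

The compounds shown leave open how a cyclohexyl group or an unsubstituted phenyl would read on this nitrogen. They also leave open how far the true step from the limit reaches.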